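Cytotoxicity notes: thiazolyl in place of pyrimidinyloxy

A few compounds are considered here, and "the series" means these few. Any claim that something is new, unique, unknown or untested is made for them only; others in the source may bear on it.

Compound 1 `O=C1CC(Oc2ncccn2)CN1c1cnn2c1CN(C(=O)Nc1cc(F)c(F)c(F)c1)C(C1CC1)C2` is the reference for this step. In a toxicity assay on HepG2 2.2.15 cells (Homo sapiens) for cytotoxicity, read by CellTiter-Glo (a higher number here means that more compound is tolerated, a lower number that less compound is tolerated), compound 1 reaches only a limit, > 200000 nM. Compound 2 `O=C1CC(C(F)(F)F)CN1c1cnn2c1CN(C(=O)Nc1cc(F)c(F)c(F)c1)C(C1CC1)C2` gives 115000 nM in this assay. Compound 3 `C[C@H]1Cn2ncc(N3CC(c4ccccc4)CC3=O)c2CN1C(=O)NCc1cc(F)c(F)c(F)c1` likewise reaches only a limit in this assay, > 2000 nM. Compound 1 therefore stands among the best-tolerated values shown, though only as a limit. Compound 4 `Cc1cnc(C2CC(=O)N(c3cnn4c3CN(C(=O)Nc3cc(F)c(F)c(F)c3)C(C3CC3)C4)C2)s1` carries 5-methyl-1,3-thiazol-2-yl in place of (pyrimidin-2-yl)oxy on a saturated ring carbon. Going by the values given here, the one measured step at this position is an at least 1.7-fold lower number from compound 1 to compound 2 (0.24 log units; that floor lies within the scatter), which stays within the scatter. Accordingly no step beyond the scatter is expected here: the expected step is an at least 1.3-fold lower number from compound 1 to compound 4 (0.12 log units; that floor lies within the scatter). For compound 4 the estimated value is 150000 nM, with a range from 50000 nM to 300000 nM.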

Compound 4, half-maximal cytotoxic concentration: 96200 nM
Estimate against measurement, compound 4: 1.6-fold (0.19 log units) above; low and high end bracket the measured number.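

In this assay, going by these compounds alone, 5-methyl-1,3-thiazol-2-yl gives the first step at this position that clears the scatter: an at least 2.0-fold lower number from compound 1 to compound 4 (0.31 log units; beyond the scatter). Against trifluoromethyl, the same group stays within the scatter, a 1.2-fold lower number from compound 2 to compound 4 (0.08 log units; within the scatter), so these two groups are not told apart here. Compound 1 stands only at a limit, so the step from it is a floor: the limit of > 200000 nM in this assay, at which 1 of the 4 values shown sits.

Going by these compounds, the true size of that step stays open. Also open, on these data alone, is whether an amine or a carboxylic acid on this saturated ring carbon would read with compound 1 or with compound 4.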